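Swapping the 2-hydroxyphenyl group of compound 2

The compounds below may be only part of what the source reports. "The series", "measured", "known", "first", "only" and "open" are said of these compounds alone.

Measured so far in a functional assay on P388 cells (Mus musculus) for cytotoxicity (a higher number here means a weaker inhibitor, a lower number a stronger inhibitor), for this series:
- compound 1 `Cc1cc(-c2c(F)cc3c(=O)c(Cc4c(O)cccc4O)cn(C4CC4)c3c2F)cc(C)n1` gives 250 nM here
- compound 2 `Cc1cc(-c2c(F)cc3c(=O)c(Cc4ccccc4O)cn(C4CC4)c3c2F)cc(C)n1` gives 670 nM here

Among the compounds with values here, compound 2 holds the higher of the two numbers in this assay so far. Compound 3 `Cc1cc(-c2c(F)cc3c(=O)c(Cc4ccc[nH]4)cn(C4CC4)c3c2F)cc(C)n1` comes next, with the change 1H-pyrrol-2-yl in place of 2-hydroxyphenyl on a saturated chain carbon bound to an aromatic carbon placing 1H-pyrrol-2-yl where 2-hydroxyphenyl stood, on a saturated chain carbon bound to an aromatic carbon. Within the data shown here, one measured step bears on this: a 2.7-fold higher number from compound 1 to compound 2 (0.43 log units; beyond the scatter) for hydrogen in place of hydroxy on an aromatic carbon, modest but beyond the scatter. Among the measured compounds shown here, no measured compound carries a five-membered aromatic ring, so the expectation stays loose: a small step at most, leaning towards a higher number. The expected move is a 1.3-fold higher number from compound 2 to compound 3 (0.13 log units; within the scatter) on this estimate. For compound 3 the estimated value is 900 nM with an expected range from 300 nM to 2500 nM in this assay once measured.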

Compound 3, half-maximal inhibitory concentration: 930 nM
Estimate against measurement, compound 3: 1.0-fold (0.01 log units) below; the measured number falls inside the stated range.
By their numbers in this assay, from the lowest: compound 1; then compounds 2 and 3 (each within the scatter of the next).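

In this assay, within the data shown here, the saturated chain carbon bound to an aromatic carbon now carries a five-membered aromatic ring for the first time: 1H-pyrrol-2-yl in place of 2-hydroxyphenyl gives a 1.4-fold higher number from compound 2 to compound 3 (0.14 log units; within the scatter), so the loss of the hydroxy group and the change of ring size together leave no readable difference between these two compounds. Against 2,6-dihydroxyphenyl, the same ring gives a 3.7-fold higher number from compound 1 to compound 3 (0.57 log units; beyond the scatter), which leaves compound 1 apart from both compound 2 and compound 3. No supporting data are available to explain these numbers.

On these data alone, it remains open whether a hydroxy group on the 1H-pyrrol-2-yl ring would shift the number as it does on the phenyl ring. As far as these compounds go, the effects of an amine or a carboxylic acid on that ring, or of a longer chain joining it to the core, also remain unknown.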